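This account rests on a few compounds, and the source may have more. Where it says the series, first, only, none or still open, it means among the compounds named here.

Measured so far:
compound 1 `CCCCNc1nc(N)nc2ccn(CC(=O)NC)c12`: > 24000 nM
compound 2 `CC(Nc1nc(N)nc2ccn(Cc3ccccn3)c12)c1ccccn1`: > 24000 nM

In an ADME assay on HEK293 cells (Homo sapiens) for cytotoxicity, read by ATP content, with a stated time of 6 h (on this read-out lower numbers stand for higher toxicity in this test and higher numbers for lower toxicity in this test), compound 1 gives > 24000 nM, which is a limit of the assay rather than a number. Compound 2 gives > 24000 nM in this assay, also a limit. Compound 2 therefore stands at the limit of > 24000 nM in this assay, at which 2 of the 2 values shown sit, so there is no number for it, only a sign that toxicity was too weak to be measured. Compound 3 `CC(C)c1cc(CNc2nc(N)nc3ccn(Cc4ccccn4)c23)no1` has not yet been tested. Among the measured compounds shown here, it differs from compound 2 in one place: (5-isopropyl-1,2-oxazol-3-yl)methyl in place of 1-(pyridin-2-yl)ethyl on a nitrogen on an aromatic ring Because compound 2 sits at the limit of > 24000 nM in this assay, at which 2 of the 2 values shown sit, no measured step exists to lean on. The step that the limit leaves unreadable from compound 2 to compound 3 is expected to be none beyond the usual scatter. Compound 3 is thus expected to give about 30000 nM, within 15000 nM to 80000 nM, and most likely to be reported again only as a limit.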

Compound 3, half-maximal cytotoxic concentration: > 24000 nM
Compound 3 ended at the assay's limit; the forecaster's own chance of this, stated with the estimate: 80%; the middle value lies beyond the limit too.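

Compound 2 and compound 3 both end at a limit rather than a number, so no step between them can be read in this assay: the limit of > 24000 nM in this assay, at which 3 of the 3 values shown sit.

The compounds shown leave open whether (5-isopropyl-1,2-oxazol-3-yl)methyl in place of 1-(pyridin-2-yl)ethyl changes the result in this assay at all.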